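Methyl removal on the saturated ring carbon: clearance notes

The compounds below may be only part of what the source reports. "The series", "measured", "known", "first", "only" and "open" are said of these compounds alone.

Measured so far in an ADME assay on microsomes from liver (Rattus norvegicus) for metabolic stability, read by LC-MS; a higher number here means faster removal of the compound, a lower number slower removal:
compound 1 `COc1cc(N2CCN(C(=O)Cn3cnc4ccc(C(F)(F)F)cc43)CC2)ccc1-c1cnc(C)o1` gives 23 mL.min-1.g-1.
compound 2 `COc1cc(N2CCN(C(=O)Cn3cnc4ccc(C(F)(F)F)cc43)C[C@@H]2C)ccc1-c1cnc(C)o1` gives 50 mL.min-1.g-1.
compound 3 `COc1cc(N2CCN(C(=O)N[C@@H](C)c3cccc4ccccc34)C[C@H]2C)ccc1-c1cnc(C)o1` gives 150 mL.min-1.g-1.

Compound 1 and compound 2 share a core and differ in one place only, (hydrogen in place of methyl on a saturated ring carbon). In this assay that change gave a 2.2-fold lower number from compound 2 to compound 1 (0.34 log units; beyond the scatter), a modest but real shift toward slower removal.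

Compound 3 stands highest of the three numbers in this assay. Its nearest neighbour is compound 2, and compound 1 lies furthest from it. Compound 3 carries a different core from compound 2; the difference between the two cores is not broken down here, so nothing can be said about what that change did on its own.

Compound 4 `COc1cc(N2CCN(C(=O)N[C@@H](C)c3cccc4ccccc34)CC2)ccc1-c1cnc(C)o1` is not yet measured in this assay. It differs from compound 3 by hydrogen in place of methyl on a saturated ring carbon. The place of the change in compound 3 reads word for word as it does in compound 2, so this is the same change that took compound 2 to compound 1, made on the other core.

Going by the values given here, the expected step is a 2.1-fold lower number from compound 3 to compound 4 (0.33 log units; beyond the scatter), of about the size of the measured one; this rests on the single earlier pair, where a 2.2-fold lower number from compound 2 to compound 1 (0.34 log units; beyond the scatter) was found, and on nothing else, since no second instance of the change on this core exists. Compound 4 is accordingly estimated at 70 mL.min-1.g-1 in this assay, with a range from 35 mL.min-1.g-1 to 140 mL.min-1.g-1.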

Compound 4, intrinsic clearance in microsomes: 130 mL.min-1.g-1
Estimate against measurement, compound 4: 1.9-fold (0.27 log units) below; the measured number falls inside the stated range.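

In this assay, hydrogen in place of methyl on a saturated ring carbon gave a 1.2-fold lower number from compound 3 to compound 4 (0.06 log units; within the scatter), so on the core of compound 3 this step cannot be told apart from repeat measurement. Set beside the step on the core of compound 1, it does not differ by more than two such steps can differ by chance: the same change on two cores in this assay, a 2.2-fold lower number (0.34 log units; beyond the scatter) from compound 2 to compound 1 and a 1.2-fold lower number (0.06 log units; within the scatter) from compound 3 to compound 4, 1.9-fold (0.28 log units) apart, within the scatter of two such steps. This shows that the data give no firm sign of the change acting differently on the two cores, but it does not show that the change carries over with a constant size: one step lies beyond the scatter and the other within it, and with a single pair on each core, neither a shared step nor a core-dependent one is established.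

The compounds shown leave open whether a group other than methyl on the same saturated ring carbon, such as an ethyl or a hydroxymethyl, would move the number on either core. They also leave open how the change would read on a third core, for instance one in which a nitrile or an amine takes the place of the methoxy group.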